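A few compounds are considered here, and "the series" means these few. Any claim that something is new, unique, unknown or untested is made for them only; others in the source may bear on it.

Compound 1 `Clc1ccc2c(c1)C=C(/C=C/c1ccccn1)CO2` is tested in an ADME assay on HeLa cells (Homo sapiens) for cytotoxicity, read by XTT assay, with a stated time of 3 days (on this read-out higher numbers stand for lower toxicity in this test and lower numbers for higher toxicity in this test), where it reaches only a limit of the assay, > 50000 nM. Compound 2 `Clc1ccc2c(c1)C=C(/C=C/c1ccncc1)CO2` gives 75000 nM in this assay. The step that the limit leaves unreadable from compound 1 to compound 2 cannot be sized, because compound 1 sits at the limit of > 50000 nM in this assay, at which 1 of the 3 values shown sits. The change is pyridin-4-yl in place of pyridin-2-yl on a double-bonded chain carbon bound to a double-bonded chain carbon. Compound 3 `O=c1c(/C=C/c2ccccn2)coc2ccccc12` carries a different core, and how the two cores differ is not broken down here. In this assay compound 3 reaches only a limit of the assay, > 200000 nM. Compound 4 `O=c1c(/C=C/c2ccncc2)coc2ccccc12` is not yet measured; it differs from compound 3 by pyridin-4-yl in place of pyridin-2-yl on a double-bonded chain carbon bound to a double-bonded chain carbon, the same change as from compound 1 to compound 2. Since that earlier step is unreadable and compound 3 stands at the limit of > 200000 nM in this assay, at which 1 of the 3 values shown sits, the step of a number no higher from compound 3 to compound 4 (the limit leaves the size open) is expected to be small. Compound 4 is estimated at 200000 nM.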

Compound 4, half-maximal cytotoxic concentration: > 100000 nM
Compound 4: only a limit was reported; the forecaster's own chance of this, stated with the estimate: 60%; the middle value lies beyond the limit too.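

The step between compound 3 and compound 4 cannot be read: both of their values in this assay are limits. The compounds shown leave open how far pyridin-4-yl in place of pyridin-2-yl shifts this read-out on either core.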